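The compounds below may be only part of what the source reports. "The series", "measured", "known", "first", "only" and "open" are said of these compounds alone.

Measured compounds:
- compound 1, `CCOC(=O)[C@H](CCC(=O)O)NC(=O)c1ccc(Sc2nc3cc(N)cc(N)c3nc2-c2ccccc2)cc1`
- compound 2, `Nc1cc(N)c2nc(-c3ccccc3)c(Sc3ccc(F)cc3)nc2c1`
- compound 3, `CCOC(=O)[C@H](CCC(=O)O)NC(=O)c1ccc(CNc2nc3cc(N)cc(N)c3nc2-c2ccccc2)cc1`

All three have been run in a functional assay on PC-3 cells (Homo sapiens) for inhibition, read by sulforhodamine B assay, with a stated time of 48 h; a lower number here means that less compound is tolerated, a higher number that more compound is tolerated. For compound 1 the result is a limit of the assay rather than a number, < 100000 nM. For compound 2 the result is likewise a limit, < 100000 nM. For compound 3 the result is again a limit, < 100000 nM. Compound 2 therefore cannot be ranked against the other two; all that is shown is the limit of < 100000 nM in this assay, at which 3 of the 3 values shown sit, so nothing separates them within this assay.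

Next in the series is compound 4, `Nc1cc(N)c2nc(-c3ccccc3)c(NCc3ccc(F)cc3)nc2c1`. Its change from compound 2 is (4-fluorobenzyl)amino in place of (4-fluorophenyl)sulfanyl on an aromatic carbon. For the measured compounds named here, no measured pair differs in one place, so no step size in this assay is on record for comparison; given that every value so far sits at the limit, no step beyond the usual scatter can be argued in either direction.

Compound 4 is accordingly expected near the same limit, estimated at 80000 nM with a range of 30000 nM to 150000 nM, which for the step from compound 2 amounts to an expected step that the limit leaves unreadable from compound 2 to compound 4.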

Compound 4, concentration lethal to 50% of the cells: < 100000 nM
Compound 4 was reported as a limit; the forecaster's own chance of this, stated with the estimate: 70%; the middle value lies beyond the limit too.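

Compound 2 and compound 4 both stand as limits of the assay in this assay, so no step can be read between them: the limit of < 100000 nM in this assay, at which 4 of the 4 values shown sit.

The compounds shown leave open whether (4-fluorobenzyl)amino in place of (4-fluorophenyl)sulfanyl changes the read-out in this assay at all.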